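The source may report more compounds than this note shows. Statements on the series, on what has been measured and on what is new or still open speak of the compounds shown alone.

The measured compounds, each with its value in an ADME assay on HEK293 cells (Homo sapiens) for cytotoxicity, read by luminescence, with a stated time of 72 h; a higher number here means that more compound is needed for the effect, a lower number that less compound is needed:

Compound 1 `CCOC(=O)c1c(-c2cccc(Oc3ccccc3)c2)[nH]c2cc(F)cc(F)c2c1=O`; compound 1 gives > 22000 nM, which is a limit of this assay.
Compound 2 `CCOC(=O)c1c(-c2cccc(OC(F)(F)F)c2)[nH]c2cc(F)cc(F)c2c1=O`; compound 2 gives > 22000 nM, again a limit.
Compound 3 `CCOC(=O)c1c(-c2cccc(Oc3ccccc3)c2)[nH]c2cc(OC)c(F)cc2c1=O`; compound 3 gives > 22000 nM, also a limit.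

From compound 1 to compound 2 the change is trifluoromethyl in place of phenyl on an oxygen on an aromatic ring; the step measured there is a step that the two limits leave unreadable from compound 1 to compound 2. The difference between the cores of compound 1 and compound 3 is not broken down here. Compound 4 `CCOC(=O)c1c(-c2cccc(OC(F)(F)F)c2)[nH]c2cc(OC)c(F)cc2c1=O` has not yet been measured; it differs from compound 3 by trifluoromethyl in place of phenyl on an oxygen on an aromatic ring, the same change at the same place. Among the compounds with values here, the only evidence is the limit of > 22000 nM in this assay, at which 3 of the 3 values shown sit. The expected step from compound 3 to compound 4 is therefore a step that the limit leaves unreadable from compound 3 to compound 4, resting on the unreadable step that the two limits leave unreadable from compound 1 to compound 2 and on (the limit of > 22000 nM in this assay, at which 3 of the 3 values shown sit). Compound 4 is estimated at 25000 nM in this assay.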

Compound 4, half-maximal effective concentration: > 22000 nM
Compound 4 ended at the assay's limit; the forecaster's own chance of this, stated with the estimate: 85%; the middle value does not contradict the limit.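

Compound 3 and compound 4 both end at a limit of this assay, and no step can be read between them. The compounds shown leave open where any of them lies beyond that limit, and so whether phenoxy to trifluoromethoxy changes the read-out at all.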